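The source may report more compounds than this note shows. Statements on the series, on what has been measured and on what is new or still open speak of the compounds shown alone.

Compound 1 `CCCCCCCCCCNC(=N)NC(=N)Nc1ccc(Cl)cc1`: 6.13
Compound 2 `CNC(=N)NC(=N)Nc1ccc(Cl)cc1`: 1.58

In a physicochemical assay for lipophilicity, in phosphate buffer, measured as octanol-water partition, at pH 11.5 (on this read-out higher numbers stand for higher lipophilicity and lower numbers for lower lipophilicity), compound 2 stands lower of the two at 1.58, well beyond the scatter from compound 1. Compound 3 `CCNC(=N)NC(=N)Nc1ccc(Cl)cc1` follows from compound 2 through (methyl in place of hydrogen on a saturated chain carbon bound to an amine nitrogen), methyl in place of hydrogen on a saturated chain carbon bound to an amine nitrogen. For the measured compounds named here, no single-place step has been measured in this assay, so the only guide is compound 1, which carries a much longer chain and reads 6.13. A small upward step, slightly beyond the scatter, is expected. The estimated step is a number 0.52 log units higher from compound 2 to compound 3 (beyond the scatter). For compound 3 the expected value is 2.1, within an estimated range of 1.8 to 2.5.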

Compound 3, partition coefficient: 2.14
The estimate for compound 3 lay 0.04 log units below the measured number, within the range that was stated.
By their numbers in this assay, from the lowest: compound 2; then compound 3; then compound 1.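

In this assay the chain on the amine nitrogen now has two readable steps: methyl in place of hydrogen on the saturated chain carbon already gives a modest rise (a number 0.56 log units higher from compound 2 to compound 3 (beyond the scatter)), while hydrogen in place of octyl gives a large fall (a number 3.99 log units lower from compound 1 to compound 3 (beyond the scatter)). Across these three compounds the number follows chain length, from methylamino through ethylamino to the long chain of compound 1, and none goes against that order. Nothing available explains this course. Still open, on these data alone, is how the number runs through intermediate chains such as butyl or hexyl. As far as these compounds go, whether a branched isopropyl or a cyclohexyl ring on that nitrogen would fit the same order also remains open.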